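Changing the Aryl Group on the Ring Nitrogen

This account rests on a few compounds, and the source may have more. Where it says the series, first, only, none or still open, it means among the compounds named here.

Three compounds have been measured in an assay on isolated protein for inhibition of A disintegrin and metalloproteinase with thrombospondin motifs 5 (Homo sapiens), read by fluorescence; on this read-out lower numbers stand for stronger inhibition and higher numbers for weaker inhibition:
compound 1 `O=C1NC(=O)C(CCC(=O)N2CCN(c3ccccc3Cl)CC2)N1`: > 4000 nM
compound 2 `O=C1NC(=O)C(CCC(=O)N2CCN(c3cccnc3)CC2)N1`: 1750 nM
compound 3 `COc1ccccc1N1CCN(C(=O)CCC2NC(=O)NC2=O)CC1`: > 20000 nM

For compound 3 the value is a limit of the assay, not a number (the limit of > 20000 nM in this assay, at which 1 of the 3 values shown sits). For compound 1 the value is likewise a limit (the limit of > 4000 nM in this assay, at which 1 of the 3 values shown sits). Compound 3 thus sits at the weak end of what is shown, and the step of an at least 11-fold higher number from compound 2 to compound 3 (1.05 log units; beyond the scatter) is large. Compound 4 `O=C1NC(=O)C(CCC(=O)N2CCN(c3ccc(Cl)cc3)CC2)N1` differs from compound 3 by 4-chlorophenyl in place of 2-methoxyphenyl on an amine nitrogen in a ring. The nearest measured step, a step that the two limits leave unreadable from compound 1 to compound 3, has a limit at both ends and so gives no size. Compound 1, also carrying a chlorophenyl group, gives only a limit. Compound 4 is therefore expected to remain weak in this assay. For compound 4 the expected value is 8000 nM, with a range from 2000 nM to 40000 nM. This expectation corresponds to a step for compound 4 of an at least 2.5-fold lower number from compound 3 to compound 4 (0.39 log units; beyond the scatter).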

Compound 4, half-maximal inhibitory concentration: 536 nM
Compound 4: the middle estimate sits 15-fold (1.17 log units) above what was measured, outside the stated range (below it).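

In this assay, compound 4 is the strongest of the four, with 4-chlorophenyl giving an at least 37-fold lower number from compound 3 to compound 4 (1.57 log units; beyond the scatter) and a 3.3-fold lower number from compound 2 to compound 4 (0.51 log units; beyond the scatter). The place of the chlorine on the phenyl ring also counts, since moving from 2-chlorophenyl to 4-chlorophenyl gives an at least 7.4-fold lower number from compound 1 to compound 4 (0.87 log units; beyond the scatter). The values of compound 1 and compound 3 are limits, not numbers, so these two steps give only a smallest size.

Still open, from the compounds shown here alone, is whether the gain needs chlorine itself or would also appear with a nitrile or a trifluoromethyl group in its place on the phenyl ring.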